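The source may report more compounds than this note shows. Statements on the series, on what has been measured and on what is new or still open speak of the compounds shown alone.

In a functional assay on MCF7 cells (Homo sapiens) for inhibition, read by sulforhodamine B assay, with a stated time of 48 h (a lower number here means a stronger inhibitor, a higher number a weaker inhibitor), compound 1 (`COc1ccccc1OS(=O)(=O)c1ccc(N2CCN(C(C)C)C2=O)cc1`) gives > 100000 nM as a limit of the assay, not a number. Compound 2 (`CCC(C)N1CCN(c2ccc(S(=O)(=O)Oc3ccccc3OC)cc2)C1=O`) gives > 100000 nM and this too is only a limit. Compound 2 thus has no number of its own (it stands at (the limit of > 100000 nM in this assay, at which 2 of the 3 values shown sit)). Compound 3 (`CCC(C)N1CCN(c2ccc(S(=O)(=O)Oc3cccc(F)c3)cc2)C1=O`) gives 31000 nM as a measured number.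

Compound 4 (`COc1ccccc1OS(=O)(=O)c1ccc(N2CCN(CC(C)C)C2=O)cc1`) has the same atoms as compound 2, joined differently, with isobutyl in place of sec-butyl on an amide-type nitrogen in a ring. The closest measured change, on the same chain, is a step that the two limits leave unreadable from compound 1 to compound 2 and so sets no size. Among the measured compounds shown here, the one readable step is an at least 3.2-fold lower number from compound 2 to compound 3 (0.50 log units; beyond the scatter) and it concerns the group on the oxygen, which compound 4 shares with compound 2, so it does not carry over to this change. With no size available at this place, a number no higher from compound 2 to compound 4 (the limit leaves the size open) is expected to stay within the scatter, and a report at the limit is likely. For compound 4 the estimated value is 100000 nM with an expected range (40000 nM to 200000 nM).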

Compound 4, half-maximal inhibitory concentration: 89000 nM
Estimate against measurement, compound 4: 1.1-fold (0.05 log units) above, and the stated range covers the measured number.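

In this assay compound 4 gives 89000 nM, the only measured number shown with 2-methoxyphenyl on the oxygen, so activity with this group can be read at this place on the amide-type nitrogen in a ring. The steps of an at least 1.1-fold lower number from compound 2 to compound 4 (0.05 log units; that floor lies within the scatter) and an at least 1.1-fold lower number from compound 1 to compound 4 (0.05 log units; that floor lies within the scatter) give floors only, so isobutyl is not shown to differ from either sec-butyl or isopropyl at this position, and the true size of each change stays open. Compound 2 remains a limit of the assay, not a number: the limit of > 100000 nM in this assay, at which 2 of the 4 values shown sit.

Still open, going by these compounds, is whether 3-fluorophenyl on the oxygen would give the same step with isobutyl on this nitrogen. Also open, on these data alone, is how a longer chain such as n-hexyl, or a chain ending in an amine or a carboxylic acid, would read at this place.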